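The source may hold more compounds than are shown below. What is called first, only, known or untested is meant among the compounds shown, and "the series" means these compounds.

Measured compounds:
- compound 1, `Cc1cccc(COc2c(-c3ccccc3)oc3cc(O)cc(O)c3c2=O)c1`: 29000 nM
- compound 2, `O=c1c(OCc2ccc([N+](=O)[O-])cc2)c(-c2ccccc2)oc2cc(O)cc(O)c12`: 40000 nM

Both compounds were tested in an ADME assay on Huh-5-2 cells (Homo sapiens) for cytotoxicity, read by WST assay, with a stated time of 3 days; a lower number here means that less compound is tolerated, a higher number that more compound is tolerated. Compound 1 gives 29000 nM, and compound 2 gives 40000 nM. Among the measured compounds shown here, of the two numbers, the one for compound 2 stands higher, but only by a 1.4-fold higher number from compound 1 to compound 2 (0.14 log units; within the scatter), so the two compounds are indistinguishable on this assay.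

Compound 3, `COc1ccc(COc2c(-c3ccccc3)oc3cc(O)cc(O)c3c2=O)cc1`, has not been measured. It differs from compound 2 in one place: methoxy in place of nitro on an aromatic carbon. For the measured compounds named here, only one measured step bears on a change of this kind, the swap of the benzyl-ring substituent that gave a 1.4-fold higher number from compound 1 to compound 2 (0.14 log units; within the scatter), and that step stayed within the scatter. A swap of one small substituent for another on the same ring is therefore expected to move the number little in this assay, in no clear direction, and the step from compound 2 to compound 3 is estimated at a 1.1-fold lower number from compound 2 to compound 3 (0.06 log units; within the scatter).

Compound 3 is expected to give about 35000 nM in this assay, most likely between 15000 nM and 80000 nM.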

Compound 3, half-maximal cytotoxic concentration: 57000 nM
Estimate against measurement, compound 3: 1.6-fold (0.21 log units) below; measured number inside the range.
By their numbers in this assay, from the lowest: compounds 1, 2 and 3 (each within the scatter of the next).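

In this assay, methoxy in place of nitro on the aromatic carbon gives a 1.4-fold higher number from compound 2 to compound 3 (0.15 log units; within the scatter), so this exchange at the position para to a large group does not separate the two compounds. The change from 3-methylphenyl to 4-methoxyphenyl on the same chain carbon gives a 2.0-fold higher number from compound 1 to compound 3 (0.29 log units; within the scatter), so the three substituted rings shown cannot be told apart in this measurement. No further measurement is available that would bear on these numbers.

Still open, as far as these compounds go, is whether a group of another kind on this ring, such as an amine or a carboxylic acid, would move the number beyond the scatter. Also open, from the compounds shown here alone, is whether a longer chain linking this ring to the oxygen on the shared core would do so.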